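A fluorine on the distal ring: the second time around

A few compounds are considered here, and "the series" means these few. Any claim that something is new, unique, unknown or untested is made for them only; others in the source may bear on it.

Measured so far:
- compound 1, `Cc1nc(-c2ccccc2)sc1COc1ccc(OCC(=O)O)c(F)c1`: 374 nM
- compound 2, `Cc1nc(-c2cccc(F)c2)sc1COc1ccc(OCC(=O)O)c(F)c1`: 185 nM
- compound 3, `Cc1nc(-c2ccccc2)sc1COc1ccc(CCC(=O)O)cc1`: 590 nM

All three were tested in an assay on CHO cells for agonist activity at Free fatty acid receptor 1 (Homo sapiens), read by FLIPR; on this read-out higher numbers stand for an effect only at larger amounts of compound and lower numbers for an effect already at smaller amounts. Compound 1 and compound 2 share one core; compound 2 carries fluoro in place of hydrogen on an aromatic carbon, and this gave a 2.0-fold lower number from compound 1 to compound 2 (0.31 log units; beyond the scatter). Compound 3 has a different core, and the difference between the two cores is not broken down here. In this assay compound 3 gives 590 nM, which stands within the scatter of compound 1 but beyond it relative to compound 2.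

The unmeasured compound 4, `Cc1nc(-c2ccc(F)cc2)sc1COc1ccc(CCC(=O)O)cc1`, is derived from compound 3 by fluoro in place of hydrogen on an aromatic carbon. Within the data shown here, this is the same kind of change as the one from compound 1 to compound 2, not the same: there the fluorine sits meta to a large group, here para to a large group, and the core it is made on is also different. Among the measured compounds shown here, the only precedent is the modest step seen from compound 1 to compound 2. Given that, and given that the place differs, a smaller gain is expected from compound 3 to compound 4, roughly a 1.5-fold lower number from compound 3 to compound 4 (0.17 log units; within the scatter), resting on compound 3 at 590 nM and the earlier step of a 2.0-fold lower number from compound 1 to compound 2 (0.31 log units; beyond the scatter). Compound 4 is therefore estimated at 400 nM, plausibly between 200 nM and 900 nM.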

Compound 4, half-maximal effective concentration: 251 nM
Compound 4: the middle estimate sits 1.6-fold (0.20 log units) above what was measured, within the range that was stated.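

In this assay, swapping a hydrogen for a fluoro on the outer phenyl ring gave a 2.4-fold lower number from compound 3 to compound 4 (0.37 log units; beyond the scatter), and this step matches the earlier one in size: the same change on two cores in this assay, a 2.0-fold lower number (0.31 log units; beyond the scatter) from compound 1 to compound 2 and a 2.4-fold lower number (0.37 log units; beyond the scatter) from compound 3 to compound 4, 1.2-fold (0.07 log units) apart, within the scatter of two such steps. Within these two pairs, then, the gain carries over from one core to the other, even though the fluorine stands para to a large group in compound 4 and at a different place on the ring in compound 2. Among these compounds, this does not show that the gain would hold on a third core, and with only two pairs, each differing from the other in both core and ring position, the effect of the core cannot be separated from the effect of the position.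

The compounds shown leave open whether a chloro or a methoxy group in the place of this fluorine would give a step of similar size, and whether a second fluoro on the same ring would add to it. They also leave open whether the 4-fluorophenyl group would give a similar step on the core of compound 1, and whether the gain would survive a longer chain ending in the carboxylic acid.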